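The source may report more compounds than this note shows. Statements on the series, on what has been measured and on what is new or still open speak of the compounds shown alone.

Measured so far:
compound 1 `COc1ccc2[nH]c(-c3ccccc3)c(C=C(C#N)C#N)c2c1` — 2200 nM
compound 2 `CCOC(=O)C(=Cc1c(-c2ccccc2)[nH]c2ccccc12)C(=O)OCC` — 4500 nM
compound 3 `CC(=O)/C(=C\c1c(-c2ccccc2)[nH]c2ccccc12)S(=O)(=O)c1ccccc1` — 945 nM

All three share the same core and were tested in a functional assay on MCF7 cells (Homo sapiens) for inhibition, read by sulforhodamine B assay, with a stated time of 48 h; a higher number here means a weaker inhibitor of growth, a lower number a stronger inhibitor of growth. Compound 3, with the structure `CC(=O)/C(=C\c1c(-c2ccccc2)[nH]c2ccccc12)S(=O)(=O)c1ccccc1`, gives 945 nM, the lowest number of the three; the gaps from it to compound 1 and to compound 2 both lie beyond the usual scatter, so it counts as the strongest growth inhibitor of this small set.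

The next compound, compound 4 with the structure `N#C/C(=C\c1c(-c2ccccc2)[nH]c2ccccc12)S(=O)(=O)c1ccccc1`, differs from compound 3 in one place: cyano in place of acetyl on a double-bonded chain carbon bound to a double-bonded chain carbon and a sulfonyl sulfur. Without a measured pair that shows this exact exchange, the direction of its effect is uncertain; compound 1, which carries two cyano groups, sits above compound 3, but its other parts differ too, so it cannot settle the question. The step from compound 3 to compound 4 is expected to be small, most likely not beyond the scatter, as a 1.3-fold higher number from compound 3 to compound 4 (0.10 log units; within the scatter) expresses. For compound 4 in this assay the expected value is 1200 nM, with a plausible range from 400 nM to 3500 nM.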

Compound 4, concentration for 50% growth inhibition: 2200 nM
For compound 4 the middle estimate is 1.8-fold (0.26 log units) below the measured one; the measured number falls inside the stated range.
By their numbers in this assay, from the lowest: compound 3; then compounds 1 and 4 (each within the scatter of the next); then compound 2.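

For the compounds shown here, this is the first direct exchange at this position. In this assay, placing cyano where acetyl sat, on a double-bonded chain carbon bound to a double-bonded chain carbon and a sulfonyl sulfur, gives a 2.3-fold higher number from compound 3 to compound 4 (0.37 log units; beyond the scatter) and so shows that this position responds to the choice between these two groups, with acetyl giving the stronger growth inhibitor of this pair. No measured property of these compounds is available to explain the shift.

As far as these compounds go, it remains open whether acetyl is the best group here or whether a longer ketone chain, a primary amide or a carboxylic acid would give a lower number still. From the compounds shown here alone, the same exchange also remains untested with anything other than the phenyl sulfonyl group as its partner on that carbon.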